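The source may hold more compounds than are shown below. What is called first, only, known or untested is meant among the compounds shown, and "the series" means these compounds.

Measured compounds:
- compound 1, `O=C(CCl)Nc1cc([N+](=O)[O-])ccc1N1CCCCC1`: 6.3%
- compound 2, `CN1CC(=O)N(C)c2cc([N+](=O)[O-])ccc21`: 0%

Both compounds were tested in a functional assay on J774 cells (Mus musculus) for cytotoxicity, tested at 10 ug/mL; on this read-out lower numbers stand for a weaker effect and higher numbers for a stronger effect at the one concentration tested. In this assay compound 1 gives 6.3% and compound 2 gives 0%. On the numbers shown, compound 2 stands at the low end of the two, but its difference from compound 1 lies within the scatter, so the two results cannot be told apart; both compounds leave the cells essentially untouched at the concentration used.

Compound 3, `CN1C(=O)CN(CCCCCCl)c2ccc([N+](=O)[O-])cc21`, has not yet been measured in this assay. It shares the core of compound 2 and differs from it in one place: 4-chlorobutyl in place of hydrogen on a saturated chain carbon bound to a nitrogen on an aromatic ring in a ring. Within the data shown here, no measured pair in this set shows what such a change does, so the only guide is that the two measured compounds, with rather different side groups, both sit near the floor of the read-out. The step of a number 8 percentage points higher from compound 2 to compound 3 (within the scatter) is therefore expected to be small, pointing upward if at all, and not clearly beyond the scatter. For compound 3 the estimated result in this assay is 8%, with a range from 0% to 25%.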

Compound 3, a percentage reported as activity, at one concentration (the size of the read-out at that concentration, not a potency): 17.8%
The estimate for compound 3 lay 9.8 percentage points below the measured number; the measured number falls inside the stated range.
By their numbers in this assay, from the lowest: compounds 2 and 1 (each within the scatter of the next); then compound 3.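

In this assay, among these compounds, the change from methyl to 5-chloropentyl on the shared core gives a number 17.8 percentage points higher from compound 2 to compound 3 (beyond the scatter), the only step in this set that can be read as a real difference. It shows that this position, a saturated chain carbon bound to a nitrogen on an aromatic ring in a ring, is not silent: what is attached there can move the read-out at the one concentration tested, though only modestly. Nothing measured here explains why the number rises.

From the compounds shown here alone, whether the step belongs to the chain itself or to its chlorine at the end remains open, and a plain pentyl chain without chlorine in the same place would help separate the two. Also open, going by these compounds, is how the read-out would respond to a shorter or longer chain, or to an amine or a carboxylic acid at the chain end, and whether any such change would carry the effect clearly further.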